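Para Substituent Swap on the Aryl-Thiazole Arm

This account rests on a few compounds, and the source may have more. Where it says the series, first, only, none or still open, it means among the compounds named here.

compound 1 `Cc1ccc(C2=NN(c3nc(-c4ccc([N+](=O)[O-])cc4)cs3)C(c3ccc(F)cc3)C2)s1`: 16.7 ug/mL
compound 2 `Cc1ccc(C2=NN(c3nc(-c4ccc(Br)cc4)cs3)C(c3ccc(F)cc3)C2)s1`: > 500 ug/mL
compound 3 `Cc1ccc(C2=NN(c3nc(-c4ccc(S(C)(=O)=O)cc4)cs3)C(c3ccc(F)cc3)C2)s1`: > 500 ug/mL

In a functional assay on A549 cells (Homo sapiens) for antiproliferative activity, read by XTT assay, with a stated time of 24 h (on this read-out higher numbers stand for weaker inhibition and lower numbers for stronger inhibition), compound 1 gives 16.7 ug/mL. For compound 2 the result is a limit of the assay, > 500 ug/mL. For compound 3 the result is likewise a limit, > 500 ug/mL. Compound 3 thus sits at the limit of > 500 ug/mL in this assay, at which 2 of the 3 values shown sit. The steps of an at least 29-fold higher number from compound 1 to compound 2 (1.47 log units; beyond the scatter) and an at least 29-fold higher number from compound 1 to compound 3 (1.47 log units; beyond the scatter) are both large losses, whereas a step that the two limits leave unreadable from compound 2 to compound 3 cannot be resolved. Compound 4 `COc1ccc(-c2csc(N3N=C(c4ccc(C)s4)CC3c3ccc(F)cc3)n2)cc1` differs from compound 3 by methoxy in place of methylsulfonyl on an aromatic carbon. Within the data shown here, no measured step introduces a methoxy group; the only readable steps run from the nitro compound to two limits. Compound 4 is therefore expected to remain near the limit, with an estimated step of an at least 1.6-fold lower number from compound 3 to compound 4 (0.22 log units; that floor lies within the scatter) that is not readable beyond the scatter. The estimate for compound 4 is 300 ug/mL, expected between 40 ug/mL and 1500 ug/mL.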

Compound 4, half-maximal inhibitory concentration: 184 ug/mL
Estimate against measurement, compound 4: 1.6-fold (0.21 log units) above; low and high end bracket the measured number.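

In this assay, methoxy at this position, para to a large group, gives a readable value where bromo and methylsulfonyl do not, so nitro is no longer the only group shown to do so, with an at least 2.7-fold lower number from compound 3 to compound 4 (0.43 log units; beyond the scatter) and an at least 2.7-fold lower number from compound 2 to compound 4 (0.43 log units; beyond the scatter). Nitro nevertheless keeps a clear lead over methoxy, with an 11-fold higher number from compound 1 to compound 4 (1.04 log units; beyond the scatter). Compound 2 and compound 3 both remain limits of the assay: the limit of > 500 ug/mL in this assay, at which 2 of the 4 values shown sit.

On these data alone, how far these two lie past that limit cannot be read, so their order stays unknown. As far as these compounds go, whether an amine or a carboxylic acid at this position would match nitro or methoxy remains open.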